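The source may hold more compounds than are shown below. What is called first, only, known or untested is meant among the compounds shown, and "the series" means these compounds.

Series notes, ester variation on the shared core.

Compound 1 `Nc1ncnc2c1ncn2CC(O)C(=O)OC1CCCCC1` gives 100 ug/mL in a functional assay on HeLa cells (Homo sapiens) for cytotoxicity; on this read-out higher numbers stand for lower toxicity in this test and lower numbers for higher toxicity in this test. Within the data shown here, compound 2 `CC(C)CCOC(=O)C(O)Cn1cnc2c(N)ncnc21` gives 400 ug/mL in this assay, the highest of the two numbers so far; the one measured step, a 4.0-fold higher number from compound 1 to compound 2 (0.60 log units; beyond the scatter), is beyond the scatter. Compound 3 `Nc1ncnc2c1ncn2CC(O)C(=O)OCc1ccco1` differs from compound 2 as follows: furan-2-yl in place of isobutyl on a saturated chain carbon bound to an oxygen next to a carbonyl group. Among the measured compounds shown here, only the step from compound 1 to compound 2 bears on an ester change, and it was modest. For compound 3 the expected step is a 2.0-fold lower number from compound 2 to compound 3 (0.30 log units; within the scatter), with direction uncertain because compound 2 at 400 ug/mL sits above compound 1 by one modest step only. Compound 3 is estimated at 200 ug/mL in this assay, between 50 ug/mL and 800 ug/mL.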

Compound 3, minimum cytotoxic concentration: 40 ug/mL
Compound 3: the middle estimate sits 5.0-fold (0.70 log units) above what was measured; measured number below the stated range.
By their numbers in this assay, from the lowest: compound 3; then compound 1; then compound 2.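

Going to the (furan-2-yl)methyl ester gives a 10-fold lower number from compound 2 to compound 3 (1.00 log units; beyond the scatter) and a 2.5-fold lower number from compound 1 to compound 3 (0.40 log units; beyond the scatter) in this assay and leaves compound 3 with the highest toxicity in this test of the three esters. Both ring-bearing esters, cyclohexyl and (furan-2-yl)methyl, now lie under the open-chain isopentyl ester of compound 2, a split that a single step could not show. No supporting data explain this result.

Going by these compounds, whether the drop follows the aromatic ring or its oxygen stays open; a benzyl ester would help separate the two. On these data alone, the standing of a longer chain ester and of the free carboxylic acid also stays open.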